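Side-chain swap from compound 2 to compound 4

The source may report more compounds than this note shows. Statements on the series, on what has been measured and on what is new or still open speak of the compounds shown alone.

Measured so far in an ADME assay (liver) for metabolic stability, with Liver microsome (Homo sapiens) as the target, read by LC-MS, using microsomes, tested at 1 uM (a lower number here means that the compound disappears faster, a higher number that the compound lasts longer), as half-life
- compound 1 `CCN(CC)CCCN/C(=N\c1ccnc2cc(Cl)ccc12)c1cccnc1` gives 0.6 h
- compound 2 `C/C(=N/c1ccnc2cc(Cl)ccc12)NCCCCN1CCCCC1` gives > 1 h
- compound 3 `CC(C)/C(=N/c1ccnc2cc(Cl)ccc12)NCCCCN1CCCCC1` gives 0.483 h

Compound 2 has the entry > 1 h, which is a limit of the assay and not a number. Compound 4 `CCN(CC)CCN/C(C)=N\c1ccnc2cc(Cl)ccc12` departs from compound 2 as follows diethylamino in place of 2-(piperidin-1-yl)ethyl on a saturated chain carbon, two bonds along the chain from an amine nitrogen and has no value yet. Within the data shown here, the one measured step of an at least 2.0-fold lower number from compound 2 to compound 3 (0.31 log units; beyond the scatter) lies at another place in the structure and bears only loosely on this change. In this assay compound 1, which also carries diethylamino, gives 0.6 h as the nearest guide. The expected step is an at least 1.2-fold lower number from compound 2 to compound 4 (0.09 log units; that floor lies within the scatter) in this assay and points to a modestly lower number. For compound 4 the estimated half-life is 0.8 h with an expected range from 0.35 h to 1.6 h in this estimate.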

Compound 4, half-life: 0.433 h
The estimate for compound 4 lay 1.8-fold (0.27 log units) above the measured number; measured number inside the range.
By their numbers in this assay, from the lowest: compounds 4, 3 and 1 (each within the scatter of the next). At a limit, above all of these: compound 2.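

The side chain, and not only the group changed in compound 3, can shift the half-life in this assay: diethylamino in place of 2-(piperidin-1-yl)ethyl gives an at least 2.3-fold lower number from compound 2 to compound 4 (0.36 log units; beyond the scatter). Compound 2 has > 1 h, a limit of the assay and not a number. The step is therefore a floor, and its full size remains unknown: the limit of > 1 h in this assay, at which 1 of the 4 values shown sits.

Still open, from the compounds shown here alone, is how a morpholine ring or a primary amine at this place would read in this assay. The compounds shown also do not tell whether diethylamino and 2-(piperidin-1-yl)ethyl differ in the same way on other cores.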